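This account rests on a few compounds, and the source may have more. Where it says the series, first, only, none or still open, it means among the compounds named here.

Measured so far:
- compound 1 `CS(=O)(=O)c1nn(Cc2nc3cc(Cl)ccc3n2CCCO)c2cnccc12`: 37.4 mL/min/kg
- compound 2 `CC(C)(O)CCCn1c(Cn2nc(S(C)(=O)=O)c3ccncc32)nc2cc(Cl)ccc21`: 60.4 mL/min/kg

Compound 1 gives the lower of the two numbers in an ADME assay on the whole organism (plasma, strain ICR) for pharmacokinetics, with Mus musculus as the target, at a dose of 2 mg/kg by the intravenous route; a higher number here means faster removal of the compound, a lower number slower removal; compound 2 stands close to it, the step of a 1.6-fold higher number from compound 1 to compound 2 (0.21 log units; within the scatter) being within the scatter.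

Compound 3 `CS(=O)(=O)c1nn(Cc2nc3cc(Cl)ccc3n2CCC(F)(F)F)c2cnccc12` differs from compound 1 by trifluoromethyl in place of hydroxymethyl on a saturated chain carbon, two bonds along the chain from an aromatic nitrogen. Going by the values given here, no measured pair shows this change. Among the compounds with values here, the only measured step, from compound 1 to compound 2, alters the same chain at its far end and stays within the scatter; it gives no sign that changes at this chain move the readout strongly, though it does not test removal of the hydroxy group. With nothing pointing firmly either way, the expected step of a 1.2-fold higher number from compound 1 to compound 3 (0.08 log units; within the scatter) is taken as none beyond the scatter, with a wide range. Compound 3 is therefore estimated at 45 mL/min/kg, expected between 20 mL/min/kg and 100 mL/min/kg.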

Compound 3, clearance: 12.2 mL/min/kg
Compound 3: the middle estimate sits 3.7-fold (0.57 log units) above what was measured; the whole stated range lies above it.
By their numbers in this assay, from the lowest: compound 3; then compounds 1 and 2 (each within the scatter of the next).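

In this assay, the chain end on the aromatic nitrogen now proves able to move removal beyond the scatter: 3-hydroxypropyl to 3,3,3-trifluoropropyl gives a 3.1-fold lower number from compound 1 to compound 3 (0.49 log units; beyond the scatter). The longer hydroxy-bearing chain points the same way, with a 5.0-fold lower number from compound 2 to compound 3 (0.69 log units; beyond the scatter), so both hydroxy-bearing chains shown sit above the trifluoromethyl-ended chain, and no compound shown goes against this. No measurement here bears on the cause of these steps.

The compounds shown leave open whether the steps follow the loss of the hydroxy group or the entry of trifluoromethyl; a plain propyl chain or a methyl ether at the chain end would separate the two. Also open, on these data alone, is how a nitrile, an amine or a longer fluorinated chain would read at this position.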